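A few compounds are considered here, and "the series" means these few. Any claim that something is new, unique, unknown or untested is made for them only; others in the source may bear on it.

In a physicochemical assay for lipophilicity (a lower number here means a more polar compound, a higher number a more lipophilic compound), compound 2 `CN1CCN(CCCS(=O)(=O)c2ccc3nc(NC(=O)NC(=O)c4cc(-n5cccc5)ccc4Cl)sc3c2)CC1` gives 2.6, which cannot be told apart from compound 3 `CC(C)NCCS(=O)(=O)c1ccc2nc(NC(=O)NC(=O)c3ccccc3Cl)sc2c1` at 2.3, while compound 1 `CN1CCCN(CCCS(=O)(=O)c2ccc3nc(NC(=O)NC(=O)c4ccccc4Cl)sc3c2)CC1` lies well lower at 1. Compound 4 `CCOc1ccc(Cl)c(C(=O)NC(=O)Nc2nc3ccc(S(=O)(=O)CCCN4CCN(C)CC4)cc3s2)c1` carries ethoxy in place of 1H-pyrrol-1-yl on an aromatic carbon. Within the data shown here, the only measured step, a number 1.30 log units higher from compound 1 to compound 3 (beyond the scatter), is large but sits on a saturated chain, not at this place, so it shows only that one change can move this assay beyond the scatter. Among the measured compounds shown here, no measured pair tests this exchange. With the smaller ethoxy entering and a ring leaving, the expected step is modest, an estimated a number 0.50 log units lower from compound 2 to compound 4 (beyond the scatter). Compound 4 is expected at 2.1, with an estimated range of 1.6 to 2.6.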

Compound 4, distribution coefficient: 2.4
Compound 4: middle estimate off by 0.30 log units, on the low side; the measured number falls inside the stated range.
By their numbers in this assay, from the lowest: compound 1; then compounds 3, 4 and 2 (each within the scatter of the next).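

At the aromatic carbon para to the chloro group, ethoxy in place of 1H-pyrrol-1-yl gives a number 0.20 log units lower from compound 2 to compound 4 (within the scatter) in this assay, so compound 2 and compound 4 cannot be told apart. Among these compounds, this is the first step read at this position, and it shows that an aromatic ring can be exchanged there for an open ethoxy group without a shift beyond the scatter. No supporting evidence accounts for this outcome.

On these data alone, whether an amine or a carboxylic acid at this carbon would shift this assay beyond the scatter remains open. So does whether a longer alkoxy chain would leave the number within it.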